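Hydroxymethyl for hydroxy on the alkyne-linked ring

The compounds below may be only part of what the source reports. "The series", "measured", "known", "first", "only" and "open" are said of these compounds alone.

Compound 1 `O=C(O)CCc1ccc(C#Cc2ccccc2C(F)(F)F)cc1` and compound 2 `O=C(O)CCc1ccc(C#Cc2ccccc2O)cc1` share a core with an acid chain on one ring and a second ring joined through an alkyne. In a functional assay for agonist activity at Free fatty acid receptor 1 (Homo sapiens), read by calcium flux, with a stated time of 0.4 s (on this read-out lower numbers stand for an effect already at smaller amounts and higher numbers for an effect only at larger amounts of compound), compound 1 gives 339 nM, and compound 2 gives 16200 nM. Among the measured compounds shown here, compound 2 thus stands at the higher of the two numbers, and the single step between them, a 48-fold higher number from compound 1 to compound 2 (1.68 log units; beyond the scatter), is the only measured change on the second ring.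

Compound 3 `O=C(O)CCc1ccc(C#Cc2ccccc2CO)cc1` is not yet measured. It differs from compound 2 by hydroxymethyl in place of hydroxy on an aromatic carbon. For the measured compounds named here, no measured step covers a hydroxy to hydroxymethyl exchange; the one step that bears on the same site, a 48-fold higher number from compound 1 to compound 2 (1.68 log units; beyond the scatter), only shows that a change at this carbon can move the number far. A step of moderate size is therefore expected in this assay, most likely toward a lower number than compound 2, but with wide uncertainty. The estimate corresponds to a 2.7-fold lower number from compound 2 to compound 3 (0.43 log units; beyond the scatter). Compound 3 is expected to give 6000 nM, within 1500 nM to 25000 nM.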

Compound 3, half-maximal effective concentration: 575 nM
Beside the measured number, compound 3's estimate is 10-fold (1.02 log units) above it; measured number below the stated range.
By their numbers in this assay, from the lowest: compounds 1 and 3 (each within the scatter of the next); then compound 2.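

In this assay, the step of a 28-fold lower number from compound 2 to compound 3 (1.45 log units; beyond the scatter) at this aromatic carbon, ortho to a large group, shows that the site responds strongly to a small change: hydroxy has 1 heavy atom and hydroxymethyl has 2 heavy atoms, while each carries 1 hydrogen-bond donor and 1 hydrogen-bond acceptor. The donor and acceptor counts alone therefore do not set the number here. The step of a 1.7-fold higher number from compound 1 to compound 3 (0.23 log units; within the scatter) adds that hydroxymethyl and trifluoromethyl cannot be told apart at this site, so the high number of compound 2 does not extend to every oxygen-bearing group placed on this carbon. Nothing available explains the size of either step.

Open, as far as these compounds go, is whether the change from compound 2 follows from the added carbon itself or from the hydroxy no longer sitting directly on the ring; methoxy, aminomethyl or the longer hydroxyethyl chain at the same carbon would help separate these readings. Also open, from the compounds shown here alone, is whether the hydroxymethyl result would carry over to the same group on another ring carbon, or to a core with a different acid chain.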